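Ethoxycarbonyl replacing acetyl on a coumarin-linked lipoamide

The compounds below may be only part of what the source reports. "The series", "measured", "known", "first", "only" and "open" are said of these compounds alone.

The three measured compounds share a core that carries a five-carbon or three-carbon ether chain ending in a triazole, which in turn links to a lipoic acid amide. Compound 1 `COc1ccc(-c2cc3ccc(OCCCn4cc(CNC(=O)CCCCC5CCSS5)nn4)cc3oc2=O)cc1` gives 52.8% in a functional assay on PC-12 cells (Rattus norvegicus) for cytotoxicity, read by MTT assay, with stated times of 3 h and 2 h, tested at 5 uM; a higher number here means a stronger effect of the compound at the concentration tested, a lower number a weaker effect. Compound 2 `O=C(CCCCC1CCSS1)NCc1cn(CCCCCOc2ccc3ccc(=O)oc3c2)nn1` gives 64.5% in this assay. Compound 3 `CC(=O)c1cc2ccc(OCCCCCn3cc(CNC(=O)CCCCC4CCSS4)nn3)cc2oc1=O` gives 22.2% in this assay, the lowest of the three numbers, with compound 1 nearest and compound 2 furthest from it, both beyond the scatter.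

Among the compounds with values here, the single one-place step among the measured compounds, a number 42.3 percentage points lower from compound 2 to compound 3 (beyond the scatter), shows that putting an acetyl group on the aromatic carbon of the core cost a large part of the effect in this assay.

Compound 4 `CCOC(=O)c1cc2ccc(OCCCCCn3cc(CNC(=O)CCCCC4CCSS4)nn3)cc2oc1=O` differs from compound 3 by ethoxy in place of methyl on a carbonyl carbon. Within the data shown here, no measured step changes this carbonyl substituent, so the step from compound 2 to compound 3 bears on it only in that it marks the group at this position as consequential. A step of modest size, in either direction, is therefore expected in this assay, estimated as a number 7.8 percentage points higher from compound 3 to compound 4 (within the scatter). Compound 4 is expected to give about 30%, within 12% to 52%.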

Compound 4, a percentage reported as activity, at one concentration (the size of the read-out at that concentration, not a potency): 36.4%
Compound 4: middle estimate off by 6.4 percentage points, on the low side; low and high end bracket the measured number.
By their numbers in this assay, from the lowest: compound 3; then compound 4; then compound 1; then compound 2.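

In this assay, the change from acetyl to ethoxycarbonyl gives a number 14.2 percentage points higher from compound 3 to compound 4 (beyond the scatter), so the outcome at this place depends on what the carbonyl carbon carries and not merely on a carbonyl group being present. The hydrogen remains the reference for this position, however: ethoxycarbonyl on the aromatic carbon still gives a number 28.1 percentage points lower from compound 2 to compound 4 (beyond the scatter), so both substituents tested here, acetyl and ethoxycarbonyl, lie below the unsubstituted compound 2, and the ethoxy in place of methyl recovers only part of that loss. No measurement shown here explains why the ethoxy group gives a higher number than the methyl group.

As far as these compounds go, two groups on this carbonyl carbon define no trend, so it remains open whether a carboxylic acid, a primary amide or a longer ester such as a butyl ester would move the number further towards that of compound 2 or back towards that of compound 3. From the compounds shown here alone, it also remains open whether the order of hydrogen, ethoxycarbonyl and acetyl would hold with a shorter chain between the core and the triazole.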